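Methoxy addition on the cyclohexylmethoxy member of the series

The source may report more compounds than this note shows. Statements on the series, on what has been measured and on what is new or still open speak of the compounds shown alone.

Going by the values given here, compound 1 `O=c1c(Cc2coc3cccc(OCC4CCCCC4)c3c2=O)coc2ccccc12` is the only member of the series with a number rather than a limit in a functional assay on NCI-H23 cells (Homo sapiens) for antiproliferative activity, read by XTT assay (a lower number here means a stronger inhibitor, a higher number a weaker inhibitor), where compound 1 gives 4130 nM. Compound 2 `CC(C)COc1cccc2occ(Cc3coc4ccccc4c3=O)c(=O)c12` carries isopropyl in place of cyclohexyl on a saturated chain carbon bound to an oxygen on an aromatic ring. In this assay compound 2 reaches only the limit > 10000 nM. Compound 3 `CC(C)CCOc1cccc2occ(Cc3coc4ccccc4c3=O)c(=O)c12` carries isobutyl in place of cyclohexyl on a saturated chain carbon bound to an oxygen on an aromatic ring. In this assay compound 3 likewise sits at the limit > 10000 nM. The steps of an at least 2.4-fold higher number from compound 1 to compound 2 (0.38 log units; beyond the scatter) and an at least 2.4-fold higher number from compound 1 to compound 3 (0.38 log units; beyond the scatter) are bounded because the limit of > 10000 nM in this assay, at which 2 of the 3 values shown sit, caps both of them, and the step that the two limits leave unreadable from compound 2 to compound 3 cannot be sized at all.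

Compound 4 `COc1ccc2c(=O)c(Cc3coc4cccc(OCC5CCCCC5)c4c3=O)coc2c1` keeps the cyclohexyl of compound 1 and differs by methoxy in place of hydrogen on an aromatic carbon. Among the compounds with values here, none of the measured steps touches this position; all three concern the group on the saturated chain carbon bound to an oxygen on an aromatic ring, and they show only that the cyclohexyl of compound 1 is the variant that yielded a number. The methoxy change is therefore unanchored, and no step beyond the scatter is expected in either direction. Compound 4 is expected to give about 4000 nM, within 1500 nM to 11000 nM, an estimated step of a 1.0-fold lower number from compound 1 to compound 4 (0.01 log units; within the scatter).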

Compound 4, half-maximal inhibitory concentration: 1320 nM
Compound 4: middle estimate off by 3.0-fold (0.48 log units), on the high side; the measured number lies below the stated range.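

This position, on an aromatic carbon of a six-membered aromatic ring of carbon only, is not silent in this assay: methoxy in place of hydrogen gives a 3.1-fold lower number from compound 1 to compound 4 (0.50 log units; beyond the scatter) with the cyclohexyl held in place. The earlier steps shown here all concerned the group on the saturated chain carbon bound to an oxygen on an aromatic ring, so the read-out now responds at a second place on the structure, and here the modest step runs toward a stronger inhibitor. The compounds shown offer no measurement that accounts for this step, so it stands as an observation on a single pair.

On these data alone, whether methoxy acts in the same way on the isopropyl and isobutyl members stays open: compound 2 and compound 3 stand only at a limit of the assay, and the step between those two cannot be read. Also open, as far as these compounds go, is whether hydroxyl, an amine or a chlorine atom on this aromatic carbon would move the number in the same direction, and whether methoxy on another aromatic carbon of the shared core would do so.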